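This account rests on a few compounds, and the source may have more. Where it says the series, first, only, none or still open, it means among the compounds named here.

Of the compounds shown here, three have been tested in an assay on CHO cells for displacement of a labelled ligand from prostaglandin D2 receptor 2 (Homo sapiens), read by scintillation counting; a lower number here means a stronger inhibitor, a higher number a weaker inhibitor. Compound 1, `CCCS(=O)(=O)c1cccc(C#Cc2cc(Cl)ccc2OCC(=O)O)c1`, gives 9 nM in this assay. Compound 2, `N#Cc1ccc(OCC(=O)O)c(C#Cc2ccccc2Cl)c1`, gives 24 nM, and compound 3, `O=C(O)COc1ccc(Cl)cc1C#Cc1ccccc1Cl`, gives 28 nM. Compound 1 stands lowest of the three, and both gaps to it lie beyond the scatter.

Compound 3 and compound 2 differ in one place:

cyano in place of chloro on an aromatic carbon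

This change made the step of a 1.2-fold lower number from compound 3 to compound 2 (0.07 log units; within the scatter), which lies within the scatter.

Compound 4, `CCCS(=O)(=O)c1cccc(C#Cc2cc(C#N)ccc2OCC(=O)O)c1`, has not yet been measured. It differs from compound 1 in one place:

cyano in place of chloro on an aromatic carbon

The difference between the core of compound 1 and the core of compound 3 is not broken down here. The surroundings of the place differ in wording, meta to a large group in one pair and meta to a group of 9 heavy atoms in the other, so the two changes are the same kind of change rather than the same.

Because the step of a 1.2-fold lower number from compound 3 to compound 2 (0.07 log units; within the scatter) was within the scatter, compound 4 is expected to move by about a 1.1-fold lower number from compound 1 to compound 4 (0.05 log units; within the scatter) in this assay, roughly a flat step. Compound 4 is therefore estimated at 8 nM, with the expected range 4 nM to 18 nM.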

Compound 4, inhibition constant: 21 nM
Beside the measured number, compound 4's estimate is 2.6-fold (0.42 log units) below it; measured number above the stated range.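

In this assay, cyano in place of chloro on the core of compound 1 gave a 2.3-fold higher number from compound 1 to compound 4 (0.37 log units; beyond the scatter), a real loss that the same change did not produce on the other core. Set side by side, the two steps show that this change did not carry over from one core to the other with the same size: the same change on two cores in this assay, a 1.2-fold lower number (0.07 log units; within the scatter) from compound 3 to compound 2 and a 2.3-fold higher number (0.37 log units; beyond the scatter) from compound 1 to compound 4, 2.7-fold (0.43 log units) apart, beyond the scatter of two such steps. With only these two pairs, this shows that a flat step on one core need not hold on another in this series, but it does not show which difference between the cores goes with the gap, nor how the change would behave on any further core.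

The compounds shown leave open whether a trifluoromethyl group or a methoxy group at this place, para to the carboxymethoxy group, would follow either step. They also leave open whether the gap between the two steps would persist on a core carrying an amide or a longer chain in place of the propylsulfonyl group.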